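Replacing the oxazole of compound 3 with a cyanopyridine

A few compounds are considered here, and "the series" means these few. Any claim that something is new, unique, unknown or untested is made for them only; others in the source may bear on it.

Compound 1, `COc1ccccc1Cc1cc2c(N)nc(-c3ccc(C)o3)nc2s1`, gives 122 nM in a functional assay on CHO-K1 cells for antagonist activity at adenosine receptor A1 (Homo sapiens), read by a beta-galactosidase reporter and cAMP accumulation, with stated times of 15 min and 6 h; a lower number here means a stronger inhibitor, a higher number a weaker inhibitor.
Compound 2, `Cc1ccc(-c2nc(N)c3cc(Cc4ccccc4Cl)sc3n2)o1`, gives 26.1 nM in this assay.
Compound 3, `Nc1nc(-c2cnco2)nc2sc(Cc3ccccc3)cc12`, gives 106 nM in this assay.

Among these three, compound 3 holds the second highest number. Its nearest neighbour is compound 1, whose number is within the scatter of that of compound 3, so the two cannot be told apart. Compound 2 lies furthest away, with a lower number that is beyond the scatter.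

Compound 4, `N#Cc1cccc(-c2nc(N)c3cc(Cc4ccccc4)sc3n2)n1`, has not yet been measured. It differs from compound 3 in one place: 6-cyanopyridin-2-yl in place of 1,3-oxazol-5-yl on an aromatic carbon.

Among the compounds with values here, the only measured step, a 4.7-fold lower number from compound 1 to compound 2 (0.67 log units; beyond the scatter), concerns a substituent on the benzyl ring and not the group that changes here. Within the data shown here, no measured pair varies the group on the six-membered aromatic ring with 2 nitrogen, so there is no direct guide for this change. The three measured numbers all sit within a fairly narrow band, which gives no reason to expect a large move in either direction.

Compound 4 is therefore expected to give about 100 nM in this assay, estimated to fall between 30 nM and 330 nM. This corresponds to an expected step of a 1.1-fold lower number from compound 3 to compound 4 (0.03 log units; within the scatter), which is not expected to exceed the scatter.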

Compound 4, inhibition constant: > 1000 nM
Compound 4 was reported as a limit (the forecaster's own chance of this, stated with the estimate: 5%); middle value at least 10-fold (1.00 log units) away from the limit.
By their numbers in this assay, from the lowest: compound 2; then compounds 3 and 1 (each within the scatter of the next). At a limit, above all of these: compound 4.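

This is the first change shown at the aromatic carbon between two ring nitrogen atoms, and it shows that the number in this assay is sensitive to the group placed there: 6-cyanopyridin-2-yl in place of 1,3-oxazol-5-yl gives an at least 9.4-fold higher number from compound 3 to compound 4 (0.97 log units; beyond the scatter). The reading for compound 4 is a limit and not an exact number, so this step gives only a minimum size: the limit of > 1000 nM in this assay, at which 1 of the 4 values shown sits. The swap also changes several things at once, since the entering group has a six-membered ring in place of a five-membered one, more heavy atoms and a triple bond, so this single step cannot show which of these differences matters.

A plain pyridine ring, or a pyridine carrying an amine or a methyl group in place of the nitrile, would help separate the contribution of the ring from that of the nitrile. On these data alone, it also remains open whether the chloro group on the benzyl ring of compound 2, when combined with 6-cyanopyridin-2-yl, would bring the number back down in this assay.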